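Replacing a chloro group with a (4-hydroxyphenyl)amino group

The compounds below may be only part of what the source reports. "The series", "measured", "known", "first", "only" and "open" are said of these compounds alone.

Measured so far:
compound 1, `N#Cc1c(Cl)nc(SCC(=O)Nn2c(COc3ccc(Cl)cc3Cl)nc3ccccc3c2=O)nc1-c1ccc(Cl)cc1`, 63.6%
compound 2, `N#Cc1c(Cl)nc(SCC(=O)Nn2c(COc3ccc(Cl)cc3Cl)nc3ccccc3c2=O)nc1-c1ccc(O)cc1`, 72.7%

In a functional assay on the whole organism (strain albino) for inhibition, with Rattus norvegicus as the target, read by paw edema, with a stated time of 1 h, at a dose of 100 mg/kg by the oral route (a higher number here means more inhibition at the dose given (going by the name of the read-out), a lower number less inhibition), compound 1 gives 63.6%, the lowest of the two numbers, while compound 2 gives 72.7%; the step of a number 9.1 percentage points higher from compound 1 to compound 2 (within the scatter) is within the scatter. Compound 3, `N#Cc1c(Nc2ccc(O)cc2)nc(SCC(=O)Nn2c(COc3ccc(Cl)cc3Cl)nc3ccccc3c2=O)nc1-c1ccc(Cl)cc1`, differs from compound 1 by (4-hydroxyphenyl)amino in place of chloro on an aromatic carbon. Among the compounds with values here, the one measured step, hydroxy in place of chloro on an aromatic carbon, is a different change and stayed within the scatter, so nothing beyond the scatter is expected for a number 3.4 percentage points higher from compound 1 to compound 3 (within the scatter). Compound 3 is therefore estimated at 67%, ranging from 52% to 82%.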

Compound 3, a percentage reported as inhibition, in the whole organism at one dose (the size of the read-out at that dose, not a potency): 90.9%
Compound 3: the middle estimate sits 23.9 percentage points below what was measured; the whole stated range lies below it.
By their numbers in this assay, from the lowest: compounds 1 and 2 (each within the scatter of the next); then compound 3.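

Within the data shown here, putting (4-hydroxyphenyl)amino in place of chloro on this aromatic carbon, ortho to a cyano group, gives a number 27.3 percentage points higher from compound 1 to compound 3 (beyond the scatter) in this assay and is the first step here to clear the scatter. The position therefore accepts a group of eight heavy atoms in place of a single chlorine, and the inhibition rises rather than falls. Nothing available here explains the rise.

Still open, as far as these compounds go, is which part of the new group matters. A plain amino group or an unsubstituted phenylamino group at this carbon would help separate the contributions of the nitrogen, the ring and the hydroxy.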